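Cytotoxicity tolerance in the shared-core series

The source may report more compounds than this note shows. Statements on the series, on what has been measured and on what is new or still open speak of the compounds shown alone.

Compound 1 `CCC1(Cc2ccccc2)OS(=O)(=O)C=C1OCc1ccc(Cl)c(Cl)c1` gives 36700 nM in an ADME assay on HEL cells (Homo sapiens) for cytotoxicity, with a stated time of 3 days; a higher number here means that more compound is tolerated, a lower number that less compound is tolerated. Compound 2 `CCC1(Cc2ccccc2)OS(=O)(=O)C=C1OCc1ccc(OC)cc1` in this assay gives > 200000 nM, which is a limit of the assay. Compound 3 `CCC1(CC)OS(=O)(=O)C=C1OCc1ccccc1` in this assay gives 200000 nM.

Compound 2 thus stands at the upper edge of the numbers shown, (the limit of > 200000 nM in this assay, at which 1 of the 3 values shown sits), and only a limit is known for it. Compound 4 `CCC1(Cc2ccccc2)OS(=O)(=O)C=C1OCC#N` is not yet measured; it differs from compound 2 by cyano in place of 4-methoxyphenyl on a saturated chain carbon bound to an oxygen on an unsaturated carbon. Among the measured compounds shown here, the one measured step at that same place, an at least 5.4-fold higher number from compound 1 to compound 2 (0.73 log units; beyond the scatter), exchanged one aromatic group for another; no measured step replaces an aromatic group by cyano, so it bears only loosely here. No step beyond the scatter is expected. Compound 4 is estimated at 200000 nM, within 90000 nM to 400000 nM, an expected step of a number no higher from compound 2 to compound 4 (the limit leaves the size open).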

Compound 4, half-maximal cytotoxic concentration: > 200000 nM
Compound 4: no number, only a limit; the forecaster's own chance of this, stated with the estimate: 65%; the middle value lies on the limit itself.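

At this place, on a saturated chain carbon bound to an oxygen on an unsaturated carbon, the aromatic ring is not needed to leave 3,4-dichlorophenyl behind: in this assay, cyano in place of that group gives an at least 5.4-fold higher number from compound 1 to compound 4 (0.73 log units; beyond the scatter). Among the compounds differing at this place, compound 1 alone now has a measured number. The step between compound 2 and compound 4 cannot be read, and the limit now holds a second compound: the limit of > 200000 nM in this assay, at which 2 of the 4 values shown sit.

As far as these compounds go, the actual numbers of compound 2 and compound 4 stay open. So does whether an amine or a carboxylic acid at this place would read like cyano or like 3,4-dichlorophenyl.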